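Methoxy for Chloro on a Quinoline Amide Core

The compounds below may be only part of what the source reports. "The series", "measured", "known", "first", "only" and "open" are said of these compounds alone.

The measured compounds:
compound 1 `Cc1cnc(C(=O)Nc2cc(Cl)cc3cccnc23)cn1` gives 1770 nM
compound 2 `COc1cc(NC(=O)c2cnc(C)cn2)c2ncccc2c1` gives 800 nM
compound 3 `O=C(Nc1cc(Cl)cc2cccnc12)c1ncccn1` gives 4670 nM

In a functional assay on PANC-1 cells (Homo sapiens) for inhibition, read by MTT assay, with a stated time of 72 h (on this read-out higher numbers stand for weaker inhibition and lower numbers for stronger inhibition), the three compounds span a modest range. Compound 3 has the highest number of the three. The two cores differ as follows: pyrimidin-2-yl in place of 5-methylpyrazin-2-yl on a carbonyl carbon. That difference is seen in a 2.6-fold higher number from compound 1 to compound 3 (0.42 log units; beyond the scatter).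

On the core of compound 1, one change is measured: methoxy in place of chloro on an aromatic carbon. It made a 2.2-fold lower number from compound 1 to compound 2 (0.34 log units; beyond the scatter). Compound 4 `COc1cc(NC(=O)c2ncccn2)c2ncccc2c1` is not yet measured; it carries the same kind of change on the core of compound 3: methoxy in place of chloro on an aromatic carbon. The two places are described almost alike, one as meta to a large group and the other as meta to a group of 9 heavy atoms, so the surroundings are of the same kind rather than the same.

Resting only on compound 1 and compound 2 and the step of a 2.2-fold lower number from compound 1 to compound 2 (0.34 log units; beyond the scatter), a step of similar size is expected from compound 3 to compound 4, namely a 2.2-fold lower number from compound 3 to compound 4 (0.35 log units; beyond the scatter). Compound 4 is therefore estimated at 2100 nM, with a range from 1000 nM to 4500 nM.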

Compound 4, half-maximal inhibitory concentration: 9000 nM
Beside the measured number, compound 4's estimate is 4.3-fold (0.63 log units) below it; the measured number lies above the stated range.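

In this assay, the effect of methoxy in place of chloro does not carry over from one core to the other; on the core of compound 3 the change gives a 1.9-fold higher number from compound 3 to compound 4 (0.28 log units; within the scatter), and this differs from the earlier step on the core of compound 1: the same change on two cores in this assay, a 2.2-fold lower number (0.34 log units; beyond the scatter) from compound 1 to compound 2 and a 1.9-fold higher number (0.28 log units; within the scatter) from compound 3 to compound 4, 4.3-fold (0.63 log units) apart, beyond the scatter of two such steps

Seen from the other side of the same four compounds, pyrimidin-2-yl in place of 5-methylpyrazin-2-yl gives an 11-fold higher number from compound 2 to compound 4 (1.05 log units; beyond the scatter) on the methoxy core, and this too differs from the step on the chloro core: the same change on two cores in this assay, a 2.6-fold higher number (0.42 log units; beyond the scatter) from compound 1 to compound 3 and an 11-fold higher number (1.05 log units; beyond the scatter) from compound 2 to compound 4, 4.3-fold (0.63 log units) apart, beyond the scatter of two such steps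

The two changes therefore do not act independently of each other in these compounds, but this single set of four does not show why, nor how either change would behave on any other core.

The compounds shown leave open whether the difference between the two carbonyl substituents lies in the methyl group or in the ring itself, which a plain pyrazin-2-yl group could help separate. Also open, from the compounds shown here alone, is how an amine or a longer alkoxy chain in place of chloro would fare on either core.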